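Four-membered ring on the sulfonyl sulfur: plasma half-life

The source may hold more compounds than are shown below. What is called first, only, known or untested is meant among the compounds shown, and "the series" means these compounds.

In an ADME assay on a cell-free system (plasma, Mus musculus) for metabolic stability, tested at 1 uM (a higher number here means that the compound lasts longer, a lower number that the compound disappears faster), compound 2 (`C=CC(=O)N[C@H]1CCN(S(=O)(=O)c2ccc(NC(=O)OCc3ccccc3)cc2)C1`) gives > 6 h, which is a limit of the assay and not a number. Compound 1 (`C=CC(=O)N1CCN(S(=O)(=O)c2ccc(NC(=O)OCc3ccccc3)cc2)CC1`) gives > 6 h, which is likewise a limit.

Compound 3 (`C=CC(=O)NC1CN(S(=O)(=O)c2ccc(NC(=O)OCc3ccccc3)cc2)C1`) has not yet been measured. The structural change from compound 2 to compound 3 is a group of 9 heavy atoms (6 carbon, 2 nitrogen, 1 oxygen; one four-membered non-aromatic ring with 1 hetero atom) in place of a group of 10 heavy atoms (7 carbon, 2 nitrogen, 1 oxygen; one five-membered non-aromatic ring with 1 hetero atom), on a sulfonyl sulfur. The replaced group is the 3-((vinylcarbonyl)amino)pyrrolidin-1-yl, and the rest of the molecule stays the same.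

Among the measured compounds shown here, one measured step bears on this change, and it also falls on a sulfonyl sulfur: a step that the two limits leave unreadable from compound 1 to compound 2. It gives no size and no direction. The whole evidence so far is the limit of > 6 h in this assay, at which 2 of the 2 values shown sit.

No step beyond the scatter is therefore expected in this assay, and no direction can be given. The expected result is a step that the limit leaves unreadable from compound 2 to compound 3, which is an estimate only. A report as a limit is the most likely outcome for compound 3. For compound 3 the estimated half-life is 8 h, with an expected range from 4 h to 16 h.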

Compound 3, half-life: > 6 h
Compound 3 was reported as a limit (the forecaster's own chance of this, stated with the estimate: 80%); the middle value is on the limit's open side.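

Among the compounds shown here, compound 1, compound 2 and compound 3 are all reported as limits in this assay, and no step among them can be read in size or direction. The compounds shown leave open how long each one actually lasts, and whether the four-membered, five-membered and six-membered rings on the sulfonyl sulfur differ at all.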